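Replacing pyrimidin-2-yl with hydrogen on compound 3

A few compounds are considered here, and "the series" means these few. Any claim that something is new, unique, unknown or untested is made for them only; others in the source may bear on it.

In an ADME assay on microsomes from liver (Mus musculus) for metabolic stability, read by LC-MS, with a stated time of 10 min (a higher number here means that more of the compound is left, a lower number that less of the compound is left), compound 3 `CN(C[C@H]1Cc2c(cccc2N2CCN(c3ncccn3)CC2)CN1)[C@H]1CCCc2cccnc21` gives 35.1% and so sits within the scatter of compound 2 `C[C@@H]1CN(c2cccc3c2C[C@H](CN(C)[C@H]2CCCc4cccnc42)NC3)C[C@H](C)N1C`, which gives 39.6% in the same read-out. Compound 1 `FC1(F)CCC(CN(C[C@H]2Cc3c(cccc3N3CCNCC3)CN2)[C@H]2CCCc3cccnc32)CC1` gives 76.6% and stands beyond the scatter from both.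

The next compound to be read is compound 4 `CN(C[C@H]1Cc2c(cccc2N2CCNCC2)CN1)[C@H]1CCCc2cccnc21`. It keeps the rest of compound 3 and has hydrogen in place of pyrimidin-2-yl on an amine nitrogen in a ring.

Among the measured compounds shown here, no two measured compounds differ in one place only, so the data give no direct size for this step. For the measured compounds named here, the nearest guide is compound 1, which also has hydrogen on that ring nitrogen but differs elsewhere, and its 76.6% is the only reading for a compound of that kind. Compounds 2 and 3 both carry a group on that nitrogen, and both read well under compound 1.

An upward move beyond the scatter is therefore expected in this assay, estimated as a number 32.9 percentage points higher from compound 3 to compound 4 (beyond the scatter) on this limited evidence. With the difference elsewhere in compound 1 left open, the estimate for compound 4 is 68%, with an expected range from 45% to 90% at this stage.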

Compound 4, percent of the compound remaining: 19.9%
Estimate against measurement, compound 4: 48.1 percentage points above; measured number below the stated range.
By their numbers in this assay, from the lowest: compound 4; then compounds 3 and 2 (each within the scatter of the next); then compound 1.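

Read in this assay, hydrogen in place of pyrimidin-2-yl on an amine nitrogen in a ring gives a number 15.2 percentage points lower from compound 3 to compound 4 (beyond the scatter) and thus a fall, so a group on this ring nitrogen is not what separates compound 3 from the higher reading of compound 1. Piperazin-1-yl in place of 3,4,5-trimethylpiperazin-1-yl on an aromatic carbon points the same way with a number 19.7 percentage points lower from compound 2 to compound 4 (beyond the scatter) and leaves compound 4 lowest of the compounds shown, with both of the substituted piperazines reading higher. Hydrogen on that ring nitrogen therefore does not by itself go with a high number: compound 1 shares it, and hydrogen in place of 4,4-difluorocyclohexyl on a saturated chain carbon bound to an amine nitrogen gives a number 56.7 percentage points lower from compound 1 to compound 4 (beyond the scatter) as the largest step in the set.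

Still open, as far as these compounds go, is whether a single methyl or an acetyl on the ring nitrogen would behave like pyrimidin-2-yl, and whether a cyclohexyl without fluorine on the chain carbon, or 4,4-difluorocyclohexyl together with pyrimidin-2-yl, would read like compound 1. Nothing at hand gives a reason for any of these steps.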